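This account rests on a few compounds, and the source may have more. Where it says the series, first, only, none or still open, it means among the compounds named here.

In a functional assay on HCT-116 cells (Homo sapiens) for cytotoxicity, read by MTT assay, with a stated time of 72 h (on this read-out lower numbers stand for stronger inhibition and higher numbers for weaker inhibition), three compounds sharing a coumarin-type amide core have been measured. Compound 1 `O=C(Nc1ccccc1)c1cc2ccc(OCc3ccccc3)cc2oc1=O` returns only the assay limit > 100000 nM. Compound 2 `CCN(CC)c1ccc2cc(C(=O)NC(C)C)c(=O)oc2c1` likewise returns only the limit > 100000 nM. For the measured compounds named here, compound 3 `CCN(CC)c1ccc2cc(C(=O)NO)c(=O)oc2c1` is the one member with a real number, 37600 nM, and so it is the only point on this scale that can be read directly. Compound 1 and compound 2 instead sit at a limit. Going by the values given here, the single measured step, an at least 2.6-fold lower number from compound 2 to compound 3 (0.42 log units; beyond the scatter), shows that putting a hydroxy on the amide-type nitrogen in place of isopropyl moved the compound off the limit of > 100000 nM in this assay, at which 2 of the 3 values shown sit, into the measurable range.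

Compound 4 `CCN(CC)c1ccc2cc(C(=O)N/N=C(/C)c3cccnc3)c(=O)oc2c1` reverses that direction: a group of 9 heavy atoms (7 carbon, 2 nitrogen; one six-membered aromatic ring with 1 hetero atom) in place of one oxygen atom, on an amide-type nitrogen. The hydroxy that accompanied the measurable value of compound 3 disappears, and a much larger carbon-and-nitrogen group takes its place, as with compound 2, which gave only a limit. The step from compound 3 to compound 4 is therefore expected to be a 1.9-fold higher number from compound 3 to compound 4 (0.27 log units; within the scatter), toward weaker inhibition. Compound 4 is estimated at 70000 nM, in a range from 20000 nM to 250000 nM, with a fair chance that only a limit is reported.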

Compound 4, half-maximal inhibitory concentration: > 100000 nM
Compound 4 was reported as a limit; the forecaster's own chance of this, stated with the estimate: 40%; at least 1.4-fold (0.15 log units) between middle value and limit.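

At this amide-type nitrogen, a second replacement of the hydroxy now gives the same kind of result as the first, and in this assay the change is an at least 2.6-fold higher number from compound 3 to compound 4 (0.42 log units; beyond the scatter). Among the compounds shown, neither isopropyl nor the larger group with its six-membered aromatic ring keeps a real number on this nitrogen, and compound 4 is reported only as a limit: the limit of > 100000 nM in this assay, at which 3 of the 4 values shown sit. The step between compound 2 and compound 4 cannot be read, and the two groups cannot be ranked against each other.

Going by these compounds, compound 3 stands alone with a real number, so it remains open whether a methoxy or an amino group on this nitrogen would also give a measurable value. Also open, on these data alone, is how a carboxylic acid in place of the whole amide would read out.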